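The compounds below may be only part of what the source reports. "The series", "measured", "known", "first", "only" and "open" are said of these compounds alone.

Compound 1 `COc1cc(-c2nnc3n2NC(c2ccco2)C(C(=O)c2ccccc2F)S3)cc(OC)c1OC` gives in a functional assay on PC-3 cells (Homo sapiens) for cytotoxicity, read by MTT assay, with a stated time of 48 h (on this read-out lower numbers stand for stronger inhibition and higher numbers for weaker inhibition), only a limit, > 100000 nM (the limit of > 100000 nM in this assay, at which 1 of the 3 values shown sits). Compound 2 `COc1cc(-c2nnc3n2NC(c2cccs2)C(C(=O)c2ccccc2)S3)cc(OC)c1OC` gives 86300 nM in this assay. Compound 3 `COc1cc(-c2nnc3n2NC(c2ccco2)C(C(=O)c2ccccc2)S3)cc(OC)c1OC` gives 64300 nM in this assay.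

Of the two numbers, compound 2 stands at the higher one, but the step of a 1.3-fold lower number from compound 2 to compound 3 (0.13 log units; within the scatter) is within the scatter. Compound 4 `COc1ccc(C(=O)C2Sc3nnc(-c4cc(OC)c(OC)c(OC)c4)n3NC2c2cccs2)cc1` differs from compound 2 by methoxy in place of hydrogen on an aromatic carbon. Among the compounds with values here, no measured step adds a methoxy; the known steps are an at least 1.5-fold lower number from compound 1 to compound 3 (0.19 log units; that floor lies within the scatter) on the benzoyl ring and a 1.3-fold lower number from compound 2 to compound 3 (0.13 log units; within the scatter) on the saturated ring carbon, both small. So no step beyond the scatter is expected in this assay from compound 2 to compound 4, which is estimated as a 1.1-fold lower number from compound 2 to compound 4 (0.03 log units; within the scatter). Compound 4 is therefore expected at about 80000 nM, between 30000 nM and 250000 nM.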

Compound 4, half-maximal inhibitory concentration: 95900 nM
The estimate for compound 4 lay 1.2-fold (0.08 log units) below the measured number; the range from low to high includes it.
By their numbers in this assay, from the lowest: compounds 3, 2 and 4 (each within the scatter of the next). At a limit, above all of these: compound 1.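

In this assay, methoxy in place of hydrogen, on an aromatic carbon para to a large group, gives a 1.1-fold higher number from compound 2 to compound 4 (0.05 log units; within the scatter). Turning phenyl into 4-methoxyphenyl therefore adds a group to the benzoyl ring without a change beyond the scatter, which the earlier steps, neither of them adding a group here, could not show. The numbers in this series also lie in the range of a limit of the read-out: the limit of > 100000 nM in this assay, at which 1 of the 4 values shown sits.

From the compounds shown here alone, whether an amine or a carboxylic acid at this position would give a step beyond the scatter stays open. So does the effect of methoxy on the furan-2-yl compound 3.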